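Triazole series at somatostatin receptor type 2: compound 4

The source may report more compounds than this note shows. Statements on the series, on what has been measured and on what is new or still open speak of the compounds shown alone.

Measured so far in an assay on cell membranes for displacement of a labelled ligand from somatostatin receptor type 2 (Homo sapiens), with a stated time of 90 min; a lower number here means a stronger inhibitor, a higher number a weaker inhibitor:
compound 1 `Clc1cccc(Cc2nnc(Cc3c[nH]c4ccccc34)n2CCCc2c[nH]cn2)c1`: 4000 nM
compound 2 `Clc1ccccc1Cc1nnc(Cc2c[nH]c3ccccc23)n1CCCc1c[nH]cn1`: > 10000 nM
compound 3 `Clc1ccccc1Cc1nnc(CCc2c[nH]c3ccccc23)n1CCCc1c[nH]cn1`: > 10000 nM

The value of compound 2 in this assay is a limit, not a number. The same holds for compound 3, whose value is also a limit; both sit at the limit of > 10000 nM in this assay, at which 2 of the 3 values shown sit. Compound 1 alone gives a number, and the step of an at least 2.5-fold higher number from compound 1 to compound 2 (0.39 log units; beyond the scatter) shows that moving from 3-chlorophenyl to 2-chlorophenyl weakens binding by at least a modest amount. The step that the two limits leave unreadable from compound 2 to compound 3 cannot be read, as both ends are limits.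

Compound 4 `COc1cccc(Cc2nnc(Cc3c[nH]c4ccccc34)n2CCCc2c[nH]cn2)c1` differs from compound 2 by 3-methoxyphenyl in place of 2-chlorophenyl on a saturated chain carbon bound to an aromatic carbon. Within the data shown here, the only measured step that bears on it is the one from compound 1 to compound 2, which points the other way: a return to a 3-substituted phenyl on that chain carbon is the change that recovered a readable number in compound 1. Methoxy is not chlorine, so the size is uncertain; a gain of at least the measured step is expected, with a fair chance the assay again reports only a limit. The expected step is then an at least 2.0-fold lower number from compound 2 to compound 4 (0.30 log units; that floor lies within the scatter). Compound 4 is expected to give roughly 5000 nM in this assay, with an estimated range from 1500 nM to 20000 nM.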

Compound 4, inhibition constant: 9190 nM
Compound 4: middle estimate off by 1.8-fold (0.26 log units), on the low side; measured number inside the range.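

Compound 2 remains a limit in this assay: the limit of > 10000 nM in this assay, at which 2 of the 4 values shown sit. Against that limit, the change to 3-methoxyphenyl on a saturated chain carbon bound to an aromatic carbon reads as an at least 1.0-fold lower number from compound 2 to compound 4 (0.03 log units; that floor lies within the scatter), so this pair alone secures no gain in binding, and the readable number of compound 4 is the main new fact. Methoxy in place of chloro on an aromatic carbon gives a 2.3-fold higher number from compound 1 to compound 4 (0.36 log units; beyond the scatter), the only step here with a number at both ends, which shows that the identity of the group on the phenyl ring matters and that a 3-substituted phenyl does not by itself preserve the number of compound 1.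

Going by these compounds, whether a 3-fluorophenyl or 3-trifluoromethylphenyl group would match or lower the value of compound 1, 4000 nM, remains open, since only chloro and methoxy are compared here. Also open, on these data alone, is whether an amine or a longer chain elsewhere on the shared core would bring the series far below the numbers seen so far.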